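Bromo for ethyl on the pyridine of a thiazole amine series

This account rests on a few compounds, and the source may have more. Where it says the series, first, only, none or still open, it means among the compounds named here.

Three compounds of one series have been run in a functional assay on RCC4 cells (Homo sapiens) for inhibition, read by XTT assay, with a stated time of 4 days; a lower number here means a stronger inhibitor, a higher number a weaker inhibitor. Compound 1 `Cc1cccc(Nc2nc(-c3ccnc(-c4cnn(C)c4)c3)cs2)c1` gives 5200 nM; 5250 nM (2 entries); the closeness of its entries is shown by the several entries of compound 1 in this assay, 5200 nM; 5250 nM (2 entries). Compound 2 `CCc1cc(-c2csc(Nc3cccc(C)c3)n2)ccn1` gives 6460 nM in this assay, which is the only number shown for it, while two further entries for compound 2 come without a single number. Compound 3 `CC(=O)c1ccc(-c2cc(-c3csc(Nc4cccc(C)c4)n3)ccn2)cc1` gives 38800 nM; 38900 nM (2 entries); its repeat entries agree with each other, as the several entries of compound 3 in this assay, 38800 nM; 38900 nM (2 entries) shows. Compounds 1 and 2 sit within the usual scatter of each other, and compound 3 stands well beyond both.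

Compound 4 `Cc1cccc(Nc2nc(-c3ccnc(Br)c3)cs2)c1` has not yet been measured in this assay. It differs from compound 2 by bromo in place of ethyl on an aromatic carbon. Within the data shown here, no measured pair in this set changes only this position, so the step can only be expected, not read off. Since the small ethyl of compound 2 at 6460 nM and the larger heterocycle of compound 1 at 5200 nM; 5250 nM (2 entries) fall within scatter of one another, the step from compound 2 to compound 4 is expected to be small, roughly a 1.1-fold higher number from compound 2 to compound 4 (0.03 log units; within the scatter), with no clear direction beyond the scatter. Compound 4 is therefore estimated at 7000 nM, with a likely range from 3000 nM to 20000 nM.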

Compound 4, half-maximal inhibitory concentration: 2040 nM
Estimate against measurement, compound 4: 3.4-fold (0.54 log units) above, and the stated range ends above it.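

The position next to the ring nitrogen proves sensitive to a single small exchange: in this assay, replacing ethyl with bromo gives a 3.2-fold lower number from compound 2 to compound 4 (0.50 log units; beyond the scatter). The earlier compounds shown here could not show this so clearly, since compound 1 and compound 2 lie within the usual scatter of each other and made this position look rather indifferent to the group it carries, whereas two carbon atoms leaving and one bromine atom entering now move the reading beyond that scatter. The step is modest and compound 2 rests on a single number, but repeat readings elsewhere in the series agree closely, which lends the step some weight: the several entries of compound 1 in this assay, 5200 nM; 5250 nM (2 entries)

The compounds shown leave open whether the step belongs to bromo itself or to the loss of ethyl, and a chloro, a methyl or an amine at the same position would help separate those two readings. Nothing shown measures a property of either group, so the cause of the step remains unknown.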